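Swapping Methoxy for Cyano in a Cytotoxicity Series

The source may hold more compounds than are shown below. What is called first, only, known or untested is meant among the compounds shown, and "the series" means these compounds.

Compound 2 `COc1ccc(CCOc2ccc(-c3c(C)nc(C)c([C@H](OC(C)(C)C)C(=O)O)c3N3CCC(C)(C)CC3)cc2)cc1` is the starting point. In a toxicity assay on MT2 cells (Homo sapiens) for cytotoxicity, read by XTT assay, with a stated time of 4 days (a lower number here means that less compound is tolerated, a higher number that more compound is tolerated), compound 2 gives only a limit, >= 33500 nM. Its neighbour compound 1 `Cc1nc(C)c([C@H](OC(C)(C)C)C(=O)O)c(N2CCC(C)(C)CC2)c1-c1ccc(Oc2ccccc2)cc1` likewise reaches only a limit in this assay, >= 20000 nM. The step that the two limits leave unreadable from compound 1 to compound 2 is therefore not readable, as the two limits the limit of >= 20000 nM in this assay, at which 1 of the 2 values shown sits, and the limit of >= 33500 nM in this assay, at which 1 of the 2 values shown sits, show. Compound 3 `Cc1nc(C)c([C@H](OC(C)(C)C)C(=O)O)c(N2CCC(C)(C)CC2)c1-c1ccc(OCCc2ccc(C#N)cc2)cc1` differs from compound 2 by cyano in place of methoxy on an aromatic carbon. Among the compounds with values here, no measured step bears on that exchange. With both neighbours tolerated up to their limits, the step of a number no higher from compound 2 to compound 3 (the limit leaves the size open) is expected to show no change beyond the scatter. Compound 3 is thus estimated at 33500 nM, within 20000 nM to 60000 nM, most likely again reported as a limit.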

Compound 3, half-maximal cytotoxic concentration: >= 33500 nM
Compound 3: only a limit was reported; the forecaster's own chance of this, stated with the estimate: 85%; the middle value lies on the limit itself.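

Within the data shown here, compound 1, compound 2 and compound 3 all reach only limits in this assay, and no step among them can be read. The compounds shown leave open the concentration at which any of them becomes cytotoxic, and whether cyano and methoxy differ at all.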